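Benzyl in Place of Propyl at a Sulfur-Bound Chain

The source may report more compounds than this note shows. Statements on the series, on what has been measured and on what is new or still open speak of the compounds shown alone.

Of the compounds shown here, three sharing a thioether-bearing core have been tested in a functional assay on MGC-803 cells (Homo sapiens) for antiproliferative activity, read by MTT assay, with a stated time of 72 h; a lower number here means a stronger inhibitor, a higher number a weaker inhibitor. Compound 1 `C/C(=N\Nc1nc(SCc2ccccc2)nc2c1nnn2Cc1ccccc1)c1ccccc1O` gives 850 nM. Compound 3 `CCCSc1nc(N/N=C(\C)c2ccccc2O)c2nnn(Cc3ccccc3)c2n1` gives 2310 nM in this assay. Compound 2 `CCCSc1nc(N/N=C/c2cc(OC)c(OC)c(OC)c2)c2nnn(Cc3ccccc3)c2n1` gives 9410 nM in this assay, the highest of the three numbers; its nearest neighbour is compound 3 and its furthest is compound 1, both gaps lying beyond the usual scatter.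

Compounds 3 and 1 differ in one place only. The change is phenyl in place of ethyl on a saturated chain carbon bound to a sulfur and it produced a 2.7-fold lower number from compound 3 to compound 1 (0.43 log units; beyond the scatter).

Compound 4 `COc1cc(/C=N/Nc2nc(SCc3ccccc3)nc3c2nnn3Cc2ccccc2)cc(OC)c1OC` has not yet been measured in this assay. It stands to compound 2 exactly as compound 1 stands to compound 3: the change is phenyl in place of ethyl on a saturated chain carbon bound to a sulfur. The cores of compound 2 and compound 3 differ in more than one place, and that difference is not broken down here. Because compound 2 gives 9410 nM and the same change gave a 2.7-fold lower number from compound 3 to compound 1 (0.43 log units; beyond the scatter), a step of similar size is expected for compound 4, namely a 2.7-fold lower number from compound 2 to compound 4 (0.43 log units; beyond the scatter). This expectation rests on a single earlier instance of the change, made on a different core, so the range is wide. Compound 4 is estimated to give 3500 nM in this assay, with a range from 1200 nM to 10000 nM.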

Compound 4, half-maximal inhibitory concentration: 1320 nM
The estimate for compound 4 lay 2.7-fold (0.42 log units) above the measured number, within the range that was stated.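

On the core of compound 2, benzyl in place of propyl gave a 7.1-fold lower number from compound 2 to compound 4 (0.85 log units; beyond the scatter) in this assay, so the change lowered the number on both cores where it can be read, and in both cases beyond the scatter. The two steps differ in printed size, but that gap is no more than two such steps can show by scatter alone, so the data give no ground for saying that one core responds more than the other: the same change on two cores in this assay, a 2.7-fold lower number (0.43 log units; beyond the scatter) from compound 3 to compound 1 and a 7.1-fold lower number (0.85 log units; beyond the scatter) from compound 2 to compound 4, 2.6-fold (0.42 log units) apart, within the scatter of two such steps This supports carrying the change from one of these cores to the other as a step in the same direction and of broadly similar size, yet it rests on two pairs only and shows neither that the change would hold on any further core nor why the number falls.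

The compounds shown carry only propylsulfanyl and benzylsulfanyl, so they leave open how a longer chain such as hexyl, or a benzyl bearing a chlorine or a carboxylic acid, would behave in that place. They also leave open whether the lower numbers seen here would appear on cells other than those of this assay.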